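Notes on replacing the 3-(dimethylamino)pyrrolidin-1-yl group

A few compounds are considered here, and "the series" means these few. Any claim that something is new, unique, unknown or untested is made for them only; others in the source may bear on it.

Going by the values given here, in an ADME assay on microsomes from liver (Rattus norvegicus) for metabolic stability, using NADPH, with a stated time of 10 min (on this read-out higher numbers stand for a more stable compound and lower numbers for a less stable compound), compound 1 (`CN(C)[C@@H]1CCN(c2cccc3c2C[C@H](CN(C)[C@H]2CCCc4cccnc42)NC3)C1`) gives 3.88% and stands lowest of the two numbers so far. Compound 2 (`CN1CCN(Nc2cccc3c2C[C@@H](CN(C)[C@H]2CCCc4cccnc42)NC3)CC1`) gives 21% in the same test, a gap beyond the usual scatter. Compound 3 (`CN(C[C@H]1Cc2c(cccc2N2C[C@H]3CCN(C)[C@H]3C2)CN1)[C@H]1CCCc2cccnc21`) keeps the core of compound 1 and carries one change: a group of 9 heavy atoms (7 carbon, 2 nitrogen; 2 five-membered non-aromatic rings with 1 hetero atom each) in place of a group of 8 heavy atoms (6 carbon, 2 nitrogen; one five-membered non-aromatic ring with 1 hetero atom), on an aromatic carbon on the same aromatic carbon, where the 3-(dimethylamino)pyrrolidin-1-yl group leaves. Among the compounds with values here, no measured pair shows this kind of exchange, so the expectation rests on two values only. With compound 1 at 3.88% the room for a further fall is small. The expected move is a slight rise, a number 4.1 percentage points higher from compound 1 to compound 3 (within the scatter) in this assay and within the scatter. For compound 3 the estimated value is 8% with an expected range from 2% to 22% in this test.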

Compound 3, percent of the compound remaining: 11.2%
Beside the measured number, compound 3's estimate is 3.2 percentage points below it; low and high end bracket the measured number.
By their numbers in this assay, from the lowest: compounds 1, 3 and 2 (each within the scatter of the next, the first and the last beyond it).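

In this assay, placing the group with 2 five-membered non-aromatic rings on the aromatic carbon that held the 3-(dimethylamino)pyrrolidin-1-yl group gives a number 7.3 percentage points higher from compound 1 to compound 3 (within the scatter). Going by these compounds alone, this is the first single-place exchange read at this position: the entering group brings one more heavy atom, a second ring and a second defined stereocentre, with the same counts of donors and acceptors, and the read-out cannot be told apart from that of the parent. No available measurement explains this outcome.

One step cannot separate the contributions of the second ring and the added stereocentre. From the compounds shown here alone, it also remains open whether a morpholin-4-yl group or a simple dimethylamino group on the same aromatic carbon would move this read-out beyond the scatter.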